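Fluoro to Methyl on the Aryl Ring: Cytotoxicity Outlook

The compounds below may be only part of what the source reports. "The series", "measured", "known", "first", "only" and "open" are said of these compounds alone.

Of the compounds shown here, two sharing a common core have been tested in an ADME assay on L929 cells (Mus musculus) for cytotoxicity; on this read-out lower numbers stand for stronger inhibition and higher numbers for weaker inhibition. Compound 1 `CCc1cnc(N2CCC(c3nc(COc4ccc(-n5cnnn5)cc4)cs3)CC2)nc1` carries a tetrazole-bearing aryl ether on that core. In this assay compound 1 gives only a limit, > 100000 nM, not a number. Compound 2 `CCc1cnc(N2CCC(c3nc(COc4ccc(/C=C5\CC(=O)NC5=O)cc4F)cs3)CC2)nc1` instead bears an aryl ether with a fluoro group next to an imide-linked alkene. In this assay compound 2 likewise reaches only the limit, > 100000 nM, and no number. Both measured values therefore sit at the same limit, as summarised in the limit of > 100000 nM in this assay, at which 2 of the 2 values shown sit; no ordering between compound 1 and compound 2 can be read from them.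

Compound 3 `CCc1cnc(N2CCC(c3nc(COc4ccc(/C=C5\CC(=O)NC5=O)cc4C)cs3)CC2)nc1` is the next step. It differs from compound 2 in one place: methyl in place of fluoro on an aromatic carbon.

Within the data shown here, with both measured compounds at the limit, no measured step guides this change, and nothing within the data ties a methyl for fluoro swap to cytotoxicity. The expected step from compound 2 to compound 3 in this assay is therefore a step that the limit leaves unreadable from compound 2 to compound 3, none beyond the scatter. Compound 3 is accordingly estimated at 150000 nM, within 50000 nM to 500000 nM, most probably reported again as a limit.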

Compound 3, half-maximal inhibitory concentration: > 100000 nM
Compound 3: a limit, no number; the forecaster's own chance of this, stated with the estimate: 85%; the middle value lies beyond the limit too.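

Among these compounds, compound 2 and compound 3 both give a limit rather than a number, so no step between them can be read, and the methyl for fluoro swap stays without a measured effect: the limit of > 100000 nM in this assay, at which 3 of the 3 values shown sit.

In this assay the compounds shown leave open whether this swap changes cytotoxicity at all, and at what concentration any of the three compounds would inhibit the cells.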